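Cyclopentyl for butyl on the amide of compound 3

The compounds below may be only part of what the source reports. "The series", "measured", "known", "first", "only" and "open" are said of these compounds alone.

Compound 1 `COc1ccc(-c2cnc(N)nc2-c2ccccc2)cc1`: 56%
Compound 2 `Nc1ncc(-c2ccncc2)c(-c2ccccc2)n1`: > 80%
Compound 3 `CCCCC(=O)Nc1ncc(-c2cccc(Cl)c2)c(-c2ccccc2)n1`: 52%

Three compounds share a common core and were tested in an assay on CHO cells for displacement of a labelled ligand from adenosine receptor A1 (Homo sapiens), read by scintillation counting, with a stated time of 1 h, tested at 1 uM; on this read-out higher numbers stand for more inhibition at the one concentration tested (going by the name of the read-out) and lower numbers for less inhibition. Compound 1 `COc1ccc(-c2cnc(N)nc2-c2ccccc2)cc1` gives 56% in this assay. For compound 2 `Nc1ncc(-c2ccncc2)c(-c2ccccc2)n1` the result in this assay is a limit of the assay, > 80%, and not a number; it is the one reading that sits at the limit, as shown by the limit of > 80% in this assay, at which 1 of the 3 values shown sits. Compound 3 `CCCCC(=O)Nc1ncc(-c2cccc(Cl)c2)c(-c2ccccc2)n1` gives 52%, a reading that lies within the usual scatter of compound 1.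

The step to compound 4 `O=C(Nc1ncc(-c2cccc(Cl)c2)c(-c2ccccc2)n1)C1CCCC1` is a single change in the amide substituent: cyclopentyl in place of butyl on a carbonyl carbon. Butyl and cyclopentyl are of similar size, and no measured pair here shows how this assay answers such a change. The expectation is therefore that compound 4 behaves much like compound 3, with a step in this assay of a number 3 percentage points higher from compound 3 to compound 4 (within the scatter) that should not exceed the scatter in either direction. Compound 4 is estimated to give 55% in this assay, within a range from 40% to 70%.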

Compound 4, a percentage reported as inhibition, at one concentration (the size of the read-out at that concentration, not a potency): 47%
Estimate against measurement, compound 4: 8 percentage points above; low and high end bracket the measured number.
By their numbers in this assay, from the lowest: compounds 4, 3 and 1 (each within the scatter of the next). At a limit, above all of these: compound 2.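

For the compounds shown here, the first pair in this set that differs in one place gives, in this assay, a step of a number 5 percentage points lower from compound 3 to compound 4 (within the scatter), for cyclopentyl in place of butyl on a carbonyl carbon. On this amide, then, the open butyl chain and the five-membered carbon ring cannot be told apart in this assay, so this one exchange of a chain for a ring leaves the reading inside the usual scatter. Nothing in the data shown bears on a cause for this result.

As far as these compounds go, whether the amide position answers to a different kind of group stays open, such as a longer chain, a phenyl ring, or a chain ending in an amine or a carboxylic acid. Compound 1 and compound 2 differ from compound 3 in more than one place, so what the amide itself contributes also remains unread.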